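The source may report more compounds than this note shows. Statements on the series, on what has been measured and on what is new or still open speak of the compounds shown alone.

Compound 2 `COc1ccc(C(=O)/C=C/c2cc(-c3cc(OC)c(OC)c(OC)c3)n[nH]2)cc1OC` gives 91% in a functional assay on SK-MEL-2 cells (Homo sapiens) for cytotoxicity, read by sulforhodamine B assay, with a stated time of 48 h, tested at 0.1 uM; on this read-out lower numbers stand for a stronger effect and higher numbers for a weaker effect at the one concentration tested. Compound 1 `COc1cc(-c2cc(/C=C/C(=O)c3ccc(Cl)c(Cl)c3)[nH]n2)cc(OC)c1OC` gives 88% in this assay, the read-out being a number 3 percentage points higher from compound 1 to compound 2 (within the scatter), so the two stand together. Compound 3 `COc1cc(-c2cc(/C=C/C(=O)c3ccc(F)c(F)c3)[nH]n2)cc(OC)c1OC` is compound 2 with 3,4-difluorophenyl in place of 3,4-dimethoxyphenyl on a carbonyl carbon. Going by the values given here, the one measured step at this carbonyl carbon, a number 3 percentage points higher from compound 1 to compound 2 (within the scatter), exchanged 3,4-dichlorophenyl for 3,4-dimethoxyphenyl without moving the read-out beyond the scatter. Compound 3 is therefore expected to show no step beyond the scatter, a number 2 percentage points lower from compound 2 to compound 3 (within the scatter). Compound 3 is estimated at 89% in this assay, with a range from 78% to 99%.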

Compound 3, a percentage reported as activity, at one concentration (the size of the read-out at that concentration, not a potency): 98%
The estimate for compound 3 lay 9 percentage points below the measured number; the range from low to high includes it.
By their numbers in this assay, from the lowest: compounds 1, 2 and 3 (each within the scatter of the next).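

At this carbonyl carbon, 3,4-difluorophenyl joins the two earlier groups with no step beyond the scatter in this assay, the read-out showing a number 7 percentage points higher from compound 2 to compound 3 (within the scatter) and a number 10 percentage points higher from compound 1 to compound 3 (within the scatter) at the one concentration tested. The three compounds therefore stand together, whether the phenyl carries chlorine, fluorine or methoxy groups. Nothing available explains why these groups read alike. From the compounds shown here alone, what stays open is whether a phenyl carrying an amine or a carboxylic acid at this carbonyl carbon would move the read-out beyond the scatter. The same holds for an unsubstituted phenyl.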